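From methoxy to trifluoromethyl on compound 1

The source may hold more compounds than are shown below. What is called first, only, known or untested is meant among the compounds shown, and "the series" means these compounds.

compound 1 `COc1cccc(N2CCN(c3c(CO)c(=O)oc4ccccc34)CC2)c1`: 38100 nM
compound 2 `O=c1oc2ccccc2c(N2CCN(c3ccc(F)cc3)CC2)c1CO`: > 50000 nM
compound 3 `COc1ccccc1N1CCN(c2c(CO)c(=O)oc3ccccc23)CC1`: > 50000 nM

All three compounds were tested in a functional assay on WM1361 cells (Homo sapiens) for inhibition, read by MTT assay, with a stated time of 24 h (a higher number here means a weaker inhibitor, a lower number a stronger inhibitor), and only compound 1 has a true number there, 38100 nM on this scale. Compound 2 gives > 50000 nM, which is a limit and not a number. Compound 3 gives > 50000 nM, which is also a limit. The set is thus dominated by the limit of > 50000 nM in this assay, at which 2 of the 3 values shown sit, and compound 1 is the only readable point.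

Compound 4 `O=c1oc2ccccc2c(N2CCN(c3cccc(C(F)(F)F)c3)CC2)c1CO` changes one group of compound 1: trifluoromethyl in place of methoxy on an aromatic carbon, in words trifluoromethyl in place of methoxy on an aromatic carbon. Going by the values given here, no measured step makes this exact exchange. The closest replace the whole group on the amine nitrogen: an at least 1.3-fold higher number from compound 1 to compound 2 (0.11 log units; that floor lies within the scatter) and an at least 1.3-fold higher number from compound 1 to compound 3 (0.11 log units; that floor lies within the scatter) are both small, and a step that the two limits leave unreadable from compound 2 to compound 3 cannot be read.

Given those two steps from compound 1, no change beyond the scatter is expected in this assay in either direction, although compound 4 could also end at the limit. The expected result is a 1.0-fold higher number from compound 1 to compound 4 (0.02 log units; within the scatter) for this exchange. Compound 4 is estimated at 40000 nM, with an expected range from 17000 nM to 90000 nM for the measurement.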

Compound 4, half-maximal inhibitory concentration: > 50000 nM
Compound 4: a limit, no number; the forecaster's own chance of this, stated with the estimate: 45%; at least 1.2-fold (0.09 log units) between middle value and limit.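

Unlike compounds 2 and 3, where the whole group on the amine nitrogen is replaced, compound 4 keeps the aromatic ring and exchanges only the group meta to a large group. In this assay this exchange gives an at least 1.3-fold higher number from compound 1 to compound 4 (0.11 log units; that floor lies within the scatter), so the printed floor does not separate the two compounds, and the true size of the step remains hidden by the limit of compound 4. Trifluoromethyl at this place therefore gives no readable number, and compound 1 remains the only compound with one: the limit of > 50000 nM in this assay, at which 3 of the 4 values shown sit.

From the compounds shown here alone, it remains open whether an amine or a carboxylic acid at this same place would give a readable number. Also open, going by these compounds, is what a longer chain, such as ethoxy, would do there.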